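Working notes: cyano step from compound 3 to compound 4

The source may hold more compounds than are shown below. What is called first, only, known or untested is meant among the compounds shown, and "the series" means these compounds.

Values in a functional assay on MV4-11 cells (Homo sapiens) for antiproliferative activity, read by CellTiter-Glo, with a stated time of 72 h; a lower number here means a stronger inhibitor of growth, a higher number a weaker inhibitor of growth:
- compound 1 `N[C@H]1CC[C@H](Nc2cc(-c3csc(NCC4CCOCC4)n3)c(Cl)cn2)CC1`: 140 nM
- compound 2 `CC(=O)N[C@H]1CC[C@H](Nc2cc(-c3csc(NCC4CCOCC4)n3)c(Cl)cn2)CC1`: 3600 nM
- compound 3 `COC[C@@H](C)N[C@H]1CC[C@H](Nc2cc(-c3csc(NCC4CCOCC4)n3)c(Cl)cn2)CC1`: 140 nM
- compound 4 `COC[C@@H](C)N[C@H]1CC[C@H](Nc2cc(-c3csc(NCC4(C#N)CCOCC4)n3)c(Cl)cn2)CC1`: not yet measured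

Compound 3 is level with compound 1, and together they hold the lowest of the three numbers. The measured steps all fall on one amine nitrogen. One reads no change at the digits printed from compound 1 to compound 3 (within the scatter), and the acetyl change reads a 26-fold higher number from compound 1 to compound 2 (1.41 log units; beyond the scatter), with a 26-fold lower number from compound 2 to compound 3 (1.41 log units; beyond the scatter) as its counterpart.

The next change lies elsewhere in the molecule: cyano in place of hydrogen on a saturated ring carbon. Here (oxan-4-yl)methyl becomes (4-cyanooxan-4-yl)methyl. For the measured compounds named here, no measured compound varies this place, so the steps above give no direct guide to its direction or size. They show only that this assay can register a large step in this series. A modest move toward a lower number is expected, held loosely, with a wide range on both sides. The expected change is a 2.3-fold lower number from compound 3 to compound 4 (0.37 log units; beyond the scatter), an estimate only. Compound 4 is estimated at 60 nM, with an expected range of 15 nM to 300 nM.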

Compound 4, concentration for 50% growth inhibition: 14 nM
For compound 4 the middle estimate is 4.3-fold (0.63 log units) above the measured one; measured number below the stated range.
By their numbers in this assay, from the lowest: compound 4; then compounds 1 and 3 (each within the scatter of the next); then compound 2.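

In this assay, the one change shown at the (oxan-4-yl)methyl group, cyano in place of hydrogen on a saturated ring carbon, gives a 10-fold lower number from compound 3 to compound 4 (1.00 log units; beyond the scatter). The earlier steps shown here all fell on the amine nitrogen, so this shows that a second place can also move the number, and that a change of only 2 heavy atoms there is enough. The step was read with the 1-(methoxymethyl)ethyl group on the amine nitrogen held fixed. No measurement on hand accounts for this step.

As far as these compounds go, whether the step belongs to cyano itself remains open, as a fluorine, a hydroxyl or a methyl on the same ring carbon would be needed to tell. Also open, from the compounds shown here alone, is whether cyano gives a step of similar size on the free amine of compound 1 or the acetyl amide of compound 2.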